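Pyridin-3-yl for 4-fluorophenyl on a shared core

The source may hold more compounds than are shown below. What is called first, only, known or untested is meant among the compounds shown, and "the series" means these compounds.

Compound 3 `Cn1cc(/C=C2/C(=O)Nc3ccccc32)c2cc(Nc3nccc(-c4ccc(F)cc4)n3)ccc21` carries a 4-fluorophenyl group, and in a functional assay on PA-1 cells (Homo sapiens) for cytotoxicity, read by MTT assay, with a stated time of 48 h (a lower number here means a stronger inhibitor, a higher number a weaker inhibitor), compound 3 gives 31800 nM. Among the two numbers recorded it stands highest, nearest to compound 1 `Cn1cc(/C=C2/C(=O)Nc3ccccc32)c2cc(Nc3nccc(-c4ccccc4)n3)ccc21`, which in this assay gives 17300 nM, a gap within the scatter since a 1.8-fold higher number from compound 1 to compound 3 (0.26 log units; within the scatter). Compound 2 `Cc1ccc(-c2ccnc(Nc3ccc4c(c3)c(/C=C3/C(=O)Nc5ccccc53)cn4C)n2)cc1` in this assay reaches only a limit, > 100000 nM. The steps of an at least 5.7-fold higher number from compound 1 to compound 2 (0.76 log units; beyond the scatter) and an at least 3.1-fold lower number from compound 2 to compound 3 (0.49 log units; beyond the scatter) both show a weaker inhibitor with methyl in place of hydrogen on an aromatic carbon. Compound 4 `Cn1cc(/C=C2/C(=O)Nc3ccccc32)c2cc(Nc3nccc(-c4cccnc4)n3)ccc21` differs from compound 3 by pyridin-3-yl in place of 4-fluorophenyl on an aromatic carbon. Going by the values given here, no measured step replaces the six-membered aromatic ring of carbon only; the one small change on it, a 1.8-fold higher number from compound 1 to compound 3 (0.26 log units; within the scatter), stayed within the scatter. Compound 4 is therefore expected to lie close to compound 3, with a 1.3-fold lower number from compound 3 to compound 4 (0.10 log units; within the scatter) expected to remain within the scatter. The estimate for compound 4 in this assay is 25000 nM, between 8000 nM and 100000 nM.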

Compound 4, half-maximal inhibitory concentration: 18100 nM
Compound 4: middle estimate off by 1.4-fold (0.14 log units), on the high side; measured number inside the range.
By their numbers in this assay, from the lowest: compounds 1, 4 and 3 (each within the scatter of the next). At a limit, above all of these: compound 2.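

In this assay, exchanging the carbon-only ring itself for pyridin-3-yl, which brings one hydrogen-bond acceptor, stays within the scatter against both neighbours: a 1.8-fold lower number from compound 3 to compound 4 (0.24 log units; within the scatter) and a 1.0-fold higher number from compound 1 to compound 4 (0.02 log units; within the scatter). Only against the 4-methylphenyl group does the new step go beyond the scatter, with an at least 5.5-fold lower number from compound 2 to compound 4 (0.74 log units; beyond the scatter). The value of compound 2 is a limit of the assay: the limit of > 100000 nM in this assay, at which 1 of the 4 values shown sits. The compounds shown leave open whether an amine or a carboxylic acid on this ring would move the number beyond the scatter.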